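Changing the Ester Side Chain: Compound 2 to Compound 3

The source may report more compounds than this note shows. Statements on the series, on what has been measured and on what is new or still open speak of the compounds shown alone.

Compound 1 `CC(C)=CC[C@@H](OC[C@H](C)O)C1=CC(=O)c2c(O)ccc(O)c2C1=O`: 40300 nM
Compound 2 `CC(C)=CC[C@@H](OC(=O)CC(C)(O)c1ccccc1)C1=CC(=O)c2c(O)ccc(O)c2C1=O`: 85700 nM

Both compounds were tested in a functional assay on HeLa cells (Homo sapiens) for cytotoxicity, read by MTT assay; a higher number here means a weaker inhibitor, a lower number a stronger inhibitor. Going by the values given here, of the two numbers, compound 2 has the higher one, so it is the weaker inhibitor of the pair; its only neighbour is compound 1, whose number is lower by a gap that lies beyond the usual scatter. Compound 3 `CCCC(CC(=O)O[C@H](CC=C(C)C)C1=CC(=O)c2c(O)ccc(O)c2C1=O)OC(C)=O` has not been measured. It keeps the shared core and the ester link seen in compound 2 but changes the group attached to the carbonyl carbon: 1-acetoxybutyl in place of 1-hydroxy-1-phenylethyl on a saturated chain carbon bound to a carbonyl carbon. Among the compounds with values here, no pair of measured compounds shows what such a change does, so any expectation rests only on the two numbers at hand, which both sit in the same weak region. The step expected here is a 1.4-fold lower number from compound 2 to compound 3 (0.15 log units; within the scatter), small and downward if anything, and it may well fall within the scatter. For compound 3 the estimated value in this assay is 60000 nM, with a range from 25000 nM to 150000 nM.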

Compound 3, half-maximal inhibitory concentration: 51200 nM
The estimate for compound 3 lay 1.2-fold (0.07 log units) above the measured number; the range from low to high includes it.
By their numbers in this assay, from the lowest: compounds 1, 3 and 2 (each within the scatter of the next, the first and the last beyond it).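

In this assay, going by these compounds alone, the first direct comparison at this place, on a saturated chain carbon bound to a carbonyl carbon, is 1-acetoxybutyl in place of 1-hydroxy-1-phenylethyl, and it gives a 1.7-fold lower number from compound 2 to compound 3 (0.22 log units; within the scatter) with the rest of the molecule unchanged. This swap is a large one on paper, since the six-membered aromatic ring and the hydrogen-bond donor both leave, yet the two numbers cannot be told apart, so neither feature is needed to hold the number at this weak level in these two compounds. Nothing available explains why the two numbers match.

On these data alone, the aromatic ring and the hydroxyl leave together in this single change, so their separate contributions remain unknown, and a group carrying only one of them, such as a plain benzyl, would be needed to pull them apart. Also open, as far as these compounds go, is whether an amine, a carboxylic acid or a longer chain at this place would stay in the same range or move the number beyond the scatter in either direction.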